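The compounds below may be only part of what the source reports. "The series", "measured", "known", "first", "only" and "open" are said of these compounds alone.

Compound 1 `CC(C)OC(=O)Nc1c(N)nc(-c2nn(Cc3ccccc3F)c3ncccc23)nc1N` gives 0.8 uM in an assay on cells for activation of Guanylate cyclase soluble subunit alpha-1 (Rattus norvegicus), read by cGMP accumulation and immunoassay, with a stated time of 10 min; a higher number here means that more compound is needed for the effect, a lower number that less compound is needed.
Compound 2 `Nc1nc(-c2nn(Cc3ccccc3F)c3ncccc23)nc(N)c1NC(=O)OC1CCC1` gives 0.2 uM.
Compound 3 `Nc1nc(-c2nn(Cc3ccccc3F)c3ncccc23)nc(N)c1NC(=O)OCC(F)(F)F` gives 0.2 uM.

Compound 3 stands level with compound 2, the pair sharing the lowest numbers of the three, with no change at the digits printed from compound 2 to compound 3 (within the scatter); compound 1 lies above both, with a 4.0-fold lower number from compound 1 to compound 3 (0.60 log units; beyond the scatter). Compound 4 `Nc1nc(-c2nn(Cc3ccccc3F)c3ncccc23)nc(N)c1N1C[C@H](C(F)(F)F)OC1=O` changes compound 3 as follows: a group of 10 heavy atoms (4 carbon, 1 nitrogen, 2 oxygen, 3 fluorine; one five-membered non-aromatic ring with 2 hetero atoms) in place of a group of 9 heavy atoms (3 carbon, 1 nitrogen, 2 oxygen, 3 fluorine; no ring), on an aromatic carbon. The measured steps, a 4.0-fold lower number from compound 1 to compound 2 (0.60 log units; beyond the scatter) and a 4.0-fold lower number from compound 1 to compound 3 (0.60 log units; beyond the scatter), only swap the group on an oxygen next to a carbonyl group; none of them closes a ring or removes the hydrogen-bond donor, so they bear on this change only loosely. The expectation is therefore a small step, a 2.5-fold higher number from compound 3 to compound 4 (0.40 log units; beyond the scatter), within or near the scatter, with wide uncertainty. Compound 4 is estimated at 0.5 uM, between 0.1 uM and 3 uM.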

Compound 4, minimum effective concentration: 0.2 uM
Compound 4: the middle estimate sits 2.5-fold (0.40 log units) above what was measured, within the range that was stated.
By their numbers in this assay, from the lowest: compounds 2, 3 and 4 (each within the scatter of the next); then compound 1.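

With no change at the digits printed from compound 3 to compound 4 (within the scatter) in this assay the open ((2,2,2-trifluoroethoxy)carbonyl)amino group gives way to a five-membered ring with no hydrogen-bond donor, so that donor is not required at this position. With no change at the digits printed from compound 2 to compound 4 (within the scatter) the ring also stands level with the cyclobutyl compound, and with a 4.0-fold lower number from compound 1 to compound 4 (0.60 log units; beyond the scatter) it keeps the gain over the isopropyl compound. No measurement here explains this result. Still open is whether the ring's defined stereocentre matters, as the opposite mirror-image form is not among these compounds. So is whether a methyl group could stand in for the ring's trifluoromethyl group.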